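Series notes: lipophilicity from compound 1 toward compound 4

A few compounds are considered here, and "the series" means these few. Any claim that something is new, unique, unknown or untested is made for them only; others in the source may bear on it.

Values in a physicochemical assay for lipophilicity, using the shake flask method, in phosphate buffer, measured as octanol-water partition, with a stated time of 30 min, at pH 7.4 (on this read-out higher numbers stand for higher lipophilicity and lower numbers for lower lipophilicity), for the measured compounds:

Compound 1 `O=C1c2ccccc2CN1c1cnc(NCc2c(F)ccc3c2CCO3)n2cnnc12` gives 2.7
Compound 2 `CN(C)Cc1ccc2c(c1)CN(c1cnc(NCc3c(F)ccc4c3CCO4)c3cn[nH]c(=O)c13)C2=O` gives 2.2
Compound 3 `Cc1nc(CN(C)C)ccc1-c1cnc(NCc2c(F)ccc3c2CCO3)c2cn[nH]c(=O)c12` gives 2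

Compound 1 stands highest of the three numbers in this assay. Its nearest neighbour is compound 2, which lies lower by a margin beyond the scatter; compound 3 lies furthest, also beyond the scatter. For the measured compounds named here, no two of the measured compounds differ in a single place, so no step between measured compounds is known, and nothing in the measured set isolates the effect of any one change.

Compound 4 `O=C(Nc1cnc(NCc2c(F)ccc3c2CCO3)n2cnnc12)c1cccnc1` is not yet measured in this assay. Against compound 1 the change is a group of 9 heavy atoms (6 carbon, 2 nitrogen, 1 oxygen; one six-membered aromatic ring with 1 hetero atom) in place of a group of 10 heavy atoms (8 carbon, 1 nitrogen, 1 oxygen; one five-membered non-aromatic ring with 1 hetero atom, one six-membered aromatic ring of carbon only), on an aromatic carbon. The group that leaves has 0 hydrogen-bond donors and 1 hydrogen-bond acceptor; the group that enters has 1 hydrogen-bond donor and 2 hydrogen-bond acceptors.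

Going by the values given here, with no measured step to lean on, the expectation for compound 4 rests on compound 1 at 2.7 and on the counted change: a lowering in this assay is expected, as a step of a number 0.90 log units lower from compound 1 to compound 4 (beyond the scatter) that should reach beyond the scatter.

Compound 4 is estimated at 1.8, with a range from 1.2 to 2.4.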

Compound 4, distribution coefficient: 2
Beside the measured number, compound 4's estimate is 0.20 log units below it, and the stated range covers the measured number.
By their numbers in this assay, from the lowest: compounds 3, 4 and 2 (each within the scatter of the next); then compound 1.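

In this assay, for the compounds shown here, replacing the group of compound 1, with its five-membered non-aromatic ring and carbon-only six-membered aromatic ring, by ((pyridin-3-yl)carbonyl)amino on this aromatic carbon gives a number 0.70 log units lower from compound 1 to compound 4 (beyond the scatter), the only step here that keeps the shared core fixed and alters one place. It shows that the read-out is sensitive to what sits at this position, but the change is a composite one: the entering group has 1 hydrogen-bond donor against 0 for the leaving group, 2 hydrogen-bond acceptors against 1, and one ring system in place of a fused pair. No measurement is available that accounts for the size of this step.

Going by these compounds alone, a benzoylamino group at this carbon, or the same amide with a methyl group on its nitrogen, would help separate the contribution of the pyridine nitrogen from that of the amide hydrogen, and the single step cannot apportion the two. From the compounds shown here alone, whether the same exchange produces a similar step on the core of compound 2 also remains open.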